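Azetidine amides on a shared oxadiazole core: piperidine to fluorophenyl

The source may report more compounds than this note shows. Statements on the series, on what has been measured and on what is new or still open speak of the compounds shown alone.

Measured so far:
compound 1 `CC1CCCC(C(=O)N2CC(c3nc(-c4cccc(Cl)c4)no3)C2)C1`, 410 nM
compound 2 `O=C(N1CCCCC1)N1CC(c2nc(-c3cccc(Cl)c3)no2)C1`, 370 nM

In an assay on HEK293 cells for positive allosteric modulation of metabotropic glutamate receptor 5 (Homo sapiens), read by FLIPR (a higher number here means that more compound is needed for the effect, a lower number that less compound is needed), compound 2 gives 370 nM, the lower of the two numbers, while compound 1 gives 410 nM. Going by the values given here, the only measured step, a 1.1-fold lower number from compound 1 to compound 2 (0.04 log units; within the scatter), swaps one saturated six-membered ring for another on the carbonyl carbon and stays within the scatter, so the two compounds cannot be ranked against each other.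

Compound 3 `O=C(c1ccc(F)cc1)N1CC(c2nc(-c3cccc(Cl)c3)no2)C1` has not been measured. It differs from compound 2 by 4-fluorophenyl in place of piperidin-1-yl on a carbonyl carbon. Among the compounds with values here, no measured step exchanges a saturated ring for an aromatic one at this position, so the bearing of a 1.1-fold lower number from compound 1 to compound 2 (0.04 log units; within the scatter) is indirect: it shows only that this carbonyl substituent has so far tolerated one change in kind without a shift beyond the scatter. For compound 3 a modest step in this assay is therefore expected, a 1.5-fold higher number from compound 2 to compound 3 (0.17 log units; within the scatter), with the direction uncertain. The estimate for compound 3 is 550 nM, expected to fall between 150 nM and 2000 nM.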

Compound 3, half-maximal effective concentration: > 10000 nM
Compound 3: only a limit was reported; the forecaster's own chance of this, stated with the estimate: 10%; middle value at least 18-fold (1.25 log units) away from the limit.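

In this assay compound 3 is reported only as a limit of the assay, not as a number: the limit of > 10000 nM in this assay, at which 1 of the 3 values shown sits. Putting 4-fluorophenyl on the carbonyl carbon in place of a saturated ring gives an at least 27-fold higher number from compound 2 to compound 3 (1.43 log units; beyond the scatter), and likewise an at least 24-fold higher number from compound 1 to compound 3 (1.38 log units; beyond the scatter). The earlier pair had shown only that 3-methylcyclohexyl and piperidin-1-yl cannot be told apart here, whereas this result shows that the position does respond to what is placed on it, and strongly so for this change.

The compounds shown leave open whether the large step belongs to the aromatic ring as such or to its fluorine, which a plain phenyl on the same carbonyl carbon would separate. They also leave open whether a methylene link between that carbonyl carbon and the phenyl ring would restore the effect.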